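From 3-Hydroxypyrrolidine to 4-Hydroxypiperidine on the Amide

The source may hold more compounds than are shown below. What is called first, only, known or untested is meant among the compounds shown, and "the series" means these compounds.

Of the compounds shown here, three have been read in an ADME assay on microsomes from liver (Homo sapiens) for metabolic stability, read by LC-MS, using NADPH, with a stated time of 30 min, tested at 0.1 uM, in the presence of a further agent that is not named here; on this read-out lower numbers stand for a less stable compound and higher numbers for a more stable compound. Compound 1 (`Nc1ccc(-c2cnc(N)c(-c3ccc(N)nc3)n2)cn1`) gives > 90% as a limit of the assay and not a number. Compound 3 (`Nc1ccc(-c2nc(-c3ccc(S(=O)(=O)C4CC4)cc3)cnc2N)cn1`) gives > 90% and this too is only a limit. Compound 2 (`Nc1ncc(-c2ccc(C(=O)N3CCC(O)C3)cc2)nc1-c1ccc(C(F)(F)F)cc1`) gives > 90% and it also has only a limit. The record so far is the limit of > 90% in this assay, at which 3 of the 3 values shown sit, and compound 2 therefore has no exact number of its own.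

Compound 4 (`Nc1ncc(-c2ccc(C(=O)N3CCC(O)CC3)cc2)nc1-c1ccc(C(F)(F)F)cc1`) carries 4-hydroxypiperidin-1-yl in place of 3-hydroxypyrrolidin-1-yl on a carbonyl carbon. Among the compounds with values here, no measured pair shows the size of such a change. In this assay no step beyond the scatter is expected, and the estimated step runs a step that the limit leaves unreadable from compound 2 to compound 4. Compound 4 is expected at 91% with an estimated range of 78% to 100%.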

Compound 4, percent of the compound remaining: > 90%
Compound 4 gave a limit, no number; the forecaster's own chance of this, stated with the estimate: 55%; the middle value lies beyond the limit too.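

In this assay no step can be read between compound 2 and compound 4, as both give only a limit: the limit of > 90% in this assay, at which 4 of the 4 values shown sit. The compounds shown leave open whether 4-hydroxypiperidin-1-yl and 3-hydroxypyrrolidin-1-yl differ at all on this read-out.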